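The source may hold more compounds than are shown below. What is called first, only, known or untested is meant among the compounds shown, and "the series" means these compounds.

Compound 1 `COc1ccc2[nH]c(C(=O)N3CC(=O)N(Cc4ccccc4)[C@@H](CN4CCC(C)CC4)C3)cc2c1` was examined in an ADME assay on Vero cells (Chlorocebus sabaeus) for cytotoxicity, with a stated time of 7 days; a higher number here means that more compound is tolerated, a lower number that less compound is tolerated. In this assay compound 1 gives > 30000 nM, which is a limit of the assay rather than a number. Compound 2 `COc1ccc2[nH]c(C(=O)N3CC(=O)N(Cc4cccc(OC)n4)[C@@H](Cc4ccccc4)C3)cc2c1` belongs to the same set. In this assay compound 2 gives > 30000 nM, again only a limit. Both shown values therefore sit at the limit of > 30000 nM in this assay, at which 2 of the 2 values shown sit, so compound 1 stands exactly where every value so far stands, and no measured step between compounds exists to describe. Compound 3 `COc1ccc2[nH]c(C(=O)N3CC(=O)N(Cc4ccccc4)[C@@H](CN4CCC(C(C)C)CC4)C3)cc2c1` has not yet been measured in this assay. It differs from compound 1 by isopropyl in place of methyl on a saturated ring carbon. Going by the values given here, with no measured step to lean on, the expected change in this assay is a number no higher from compound 1 to compound 3 (the limit leaves the size open), nothing beyond the scatter. For compound 3 the estimated result in this assay is 30000 nM, expected to fall between 12000 nM and 60000 nM.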

Compound 3, half-maximal cytotoxic concentration: 3800 nM
Estimate against measurement, compound 3: 7.9-fold (0.90 log units) above; the measured number lies below the stated range.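

In this assay, isopropyl in place of methyl on this saturated ring carbon, three ring bonds from the ring nitrogen, comes with an at least 7.8-fold lower number from compound 1 to compound 3 (0.89 log units; beyond the scatter). The earlier compounds shown here could not show that this position responds to what it carries, and here a change of carbon atoms alone, with no hydrogen-bond donor, acceptor or net charge entering or leaving, is enough to bring a number into view. Compound 3 is the only compound shown with a number instead of a limit: the limit of > 30000 nM in this assay, at which 2 of the 3 values shown sit.

One step cannot tell whether the tolerated concentration falls steadily as the alkyl group grows, since an ethyl or a tert-butyl group at this carbon does not appear among the compounds shown. Also open, as far as these compounds go, is how a hydroxyl group or a carboxylic acid at the same place would read in this assay.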